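A few compounds are considered here, and "the series" means these few. Any claim that something is new, unique, unknown or untested is made for them only; others in the source may bear on it.

In an ADME assay on S9 fraction from liver (Homo sapiens) for metabolic stability, read by LC-MS, using NADPH, with a stated time of 60 min, tested at 1 uM (a higher number here means that the compound lasts longer, a lower number that the compound disappears faster), compound 1 `Cc1ccccc1N(C)C(=O)c1ccc(-c2ccc(OS(N)(=O)=O)cc2)o1` gives 0.783 h as its half-life and compound 2 `Cc1ccccc1N(C)C(=O)c1ccc(-c2ccc(OS(N)(=O)=O)c(Cl)c2)o1` gives 0.8 h as its half-life, so the two lie within the scatter of each other. Compound 3 `Cc1cc(F)ccc1N(C)C(=O)c1ccc(-c2ccc(OS(N)(=O)=O)cc2)o1` is still unmeasured. It carries a single change from compound 1, fluoro in place of hydrogen on an aromatic carbon, which turns 2-methylphenyl into 4-fluoro-2-methylphenyl (fluoro in place of hydrogen on an aromatic carbon). For the measured compounds named here, the only measured step to compare is chloro in place of hydrogen on an aromatic carbon, made at another place in the molecule. That step (a 1.0-fold higher number from compound 1 to compound 2 (0.01 log units; within the scatter)) is a thin guide, since it involves a different group at a different place, but it offers no sign of a shift. No step beyond the scatter is therefore expected in this assay, and the expected step is small (a 1.1-fold higher number from compound 1 to compound 3 (0.04 log units; within the scatter)). Compound 3 is estimated at 0.85 h as its half-life, within an expected range (0.4 h to 1.7 h).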

Compound 3, half-life: 0.733 h
The estimate for compound 3 lay 1.2-fold (0.06 log units) above the measured number, and the stated range covers the measured number.
By their numbers in this assay, from the lowest: compounds 3, 1 and 2 (each within the scatter of the next).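

In this assay, fluoro in place of hydrogen on an aromatic carbon, para to a large group and meta to a methyl group, gives a 1.1-fold lower number from compound 1 to compound 3 (0.03 log units; within the scatter) and so stays within the scatter. For the compounds shown here, until now, the only step available was chloro at another place in the molecule, a 1.0-fold higher number from compound 1 to compound 2 (0.01 log units; within the scatter) and also within the scatter, so this is the first reading for the ring of the 2-methylphenyl group. Nothing measured here gives a reason for this result.

The compounds shown leave open whether a different group at this same position, such as an amine or a carboxylic acid, would give a step beyond the scatter. They also leave open whether fluoro would behave the same way at another carbon of this ring.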